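Aryl replacements on the shared core: compound 3 expected

A few compounds are considered here, and "the series" means these few. Any claim that something is new, unique, unknown or untested is made for them only; others in the source may bear on it.

Measured so far:
compound 1 `CC(C)(C)Cc1c(-c2ccc(Cl)c(Cl)c2)sc(N)c1C(=O)c1ccc(Cl)cc1` — 1%
compound 2 `CC(C)c1ccc(-c2sc(N)c(C(=O)c3ccc(Cl)cc3)c2CC(C)(C)C)cc1` — 1%

In an assay on CHO cells for displacement of a labelled ligand from adenosine receptor A3 (Homo sapiens), read by scintillation counting, tested at 10 uM (on this read-out higher numbers stand for more inhibition at the one concentration tested (going by the name of the read-out) and lower numbers for less inhibition), compound 1 `CC(C)(C)Cc1c(-c2ccc(Cl)c(Cl)c2)sc(N)c1C(=O)c1ccc(Cl)cc1` gives 1%. Compound 2 `CC(C)c1ccc(-c2sc(N)c(C(=O)c3ccc(Cl)cc3)c2CC(C)(C)C)cc1`, with 4-isopropylphenyl in place of 3,4-dichlorophenyl on an aromatic carbon, gives 1% in this assay. Within the data shown here, the step of no change at the digits printed from compound 1 to compound 2 (within the scatter) is no change within the scatter, so compound 2 stands level with compound 1, its only measured neighbour, and both sit at the bottom of the read-out.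

Compound 3 `COc1ccc(-c2sc(N)c(C(=O)c3ccc(Cl)cc3)c2CC(C)(C)C)cc1` differs from compound 2 by methoxy in place of isopropyl on an aromatic carbon. Among the measured compounds shown here, the one step that bears on this position, no change at the digits printed from compound 1 to compound 2 (within the scatter), exchanged one aryl group for another at the same aromatic carbon without moving the read-out. For the measured compounds named here, no measured compound carries a methoxy or any comparable group at this place, so there is no direct precedent; the single precedent at this aromatic carbon is flat. Compound 3 is therefore expected to give 2% in this assay, with a range of 0% to 12%. The expected step of a number 1 percentage points higher from compound 2 to compound 3 (within the scatter) is none beyond the scatter.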

Compound 3, a percentage reported as inhibition, at one concentration (the size of the read-out at that concentration, not a potency): 2%
Compound 3: the middle estimate sits on the measured number at the digits printed; low and high end bracket the measured number.
By their numbers in this assay, from the lowest: compounds 1, 2 and 3 (each within the scatter of the next).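

In this assay, methoxy in place of isopropyl on an aromatic carbon, para to a large group, gives a number 1 percentage points higher from compound 2 to compound 3 (within the scatter) and so shows that a group with a hydrogen-bond acceptor reads the same here as the all-carbon isopropyl. The change from 3,4-dichlorophenyl to 4-methoxyphenyl gives a number 1 percentage points higher from compound 1 to compound 3 (within the scatter) and leaves three aryl groups at this aromatic carbon that cannot be told apart on this read-out, all at the bottom of its range. Nothing available explains this flat result.

With every value this low, the compounds shown cannot tell whether any group at this aromatic carbon can raise the inhibition at the one concentration tested, or whether the shared core itself keeps the read-out at this level. Going by these compounds, an amine or a carboxylic acid at this place remains open, as do changes elsewhere on the shared core.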